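This account rests on a few compounds, and the source may have more. Where it says the series, first, only, none or still open, it means among the compounds named here.

Compound 1, `CC(C)c1c(C(=O)N2CCC[C@H](c3ccccc3)C2)nn(-c2ccc(F)cc2)c1CC[C@@H](O)C[C@@H](O)CC(=O)O`, gives 310 nM in a functional assay on L6 cells (Rattus norvegicus) for inhibition; a lower number here means a stronger inhibitor, a higher number a weaker inhibitor.
Compound 2, `CC(C)c1c(C(=O)N2CCC[C@H](N3CCC4C=CC=CC4C3)C2)nn(-c2ccc(F)cc2)c1CC[C@@H](O)C[C@@H](O)CC(=O)O`, gives 1720 nM in this assay.
Compound 3, `CC(C)c1c(C(=O)NCc2ccccn2)nn(-c2ccc(F)cc2)c1OC[C@@H](O)C[C@@H](O)CC(=O)O`, is recorded as "not determined" (no result reported) in this assay, that is, it has no result there.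

Going by these compounds, compound 3 therefore stands nowhere on these numbers; its own potency is unknown. The step to compound 4, `CC(C)c1c(C(=O)N(C)Cc2ccc(F)cc2)nn(-c2ccc(F)cc2)c1OC[C@@H](O)C[C@@H](O)CC(=O)O`, is (4-fluorobenzyl)(methyl)amino in place of ((pyridin-2-yl)methyl)amino on a carbonyl carbon. Within the data shown here, the only measured step, a 5.5-fold higher number from compound 1 to compound 2 (0.74 log units; beyond the scatter), changes a group on a saturated ring carbon and not on the carbonyl carbon, and compound 1 and compound 2 also carry a different link to the shared core than compound 3 and compound 4, so it bears on this step only loosely. It shows that reshaping the amide side of this series can move the number by a modest amount. Without a number for compound 3 no direction can be given. Compound 4 is expected to give about 600 nM in this assay, within 120 nM to 3000 nM.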

Compound 4, half-maximal inhibitory concentration: 2800 nM
The estimate for compound 4 lay 4.7-fold (0.67 log units) below the measured number; measured number inside the range.
By their numbers in this assay, from the lowest: compound 1; then compounds 2 and 4 (each within the scatter of the next).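

In this assay compound 3 has no result, so the step to compound 4 cannot be read, and no measured evidence accounts for the value of compound 4. Going by these compounds, whether (4-fluorobenzyl)(methyl)amino gives stronger or weaker inhibition than ((pyridin-2-yl)methyl)amino on this carbonyl carbon stays open.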